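The source may hold more compounds than are shown below. What is called first, only, known or untested is meant among the compounds shown, and "the series" means these compounds.

Measured so far in an in vitro assay on BTI-TN-5B1-4 cells for inhibition of Amine oxidase [flavin-containing] A (Homo sapiens), tested at 100 uM; on this read-out higher numbers stand for more inhibition at the one concentration tested (going by the name of the read-out) and lower numbers for less inhibition: compound 1, `COc1ccc(-c2cc(=O)c3ccc(OC)cc3o2)cc1`, gives "not active" (no number reported); compound 2, `Cc1ccc2c(=O)cc(-c3ccc(F)cc3)oc2c1`, gives "not active" (no number reported); compound 3, `COc1ccc(-c2cc(=O)c3ccc(F)cc3o2)cc1`, gives 40%.

Compound 3 is thus the only one of the three with a reported number; for compounds 1 and 2 nothing beyond the reported verdict of not active is known. Compound 4, `O=c1cc(-c2ccc(F)cc2)oc2cc(F)ccc12`, has not yet been tested. It differs from compound 3 in one place: fluoro in place of methoxy on an aromatic carbon. Among the measured compounds shown here, no measured pair with this same change exists to lean on, so the size of the step is uncertain. Since compound 3 gives 40% and both of its neighbours are reported as not active, a modest drop is expected, of about a number 15 percentage points lower from compound 3 to compound 4 (beyond the scatter). Compound 4 is therefore expected to give roughly 25%, likely between 5% and 50%.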

Compound 4, a percentage reported as inhibition, at one concentration (the size of the read-out at that concentration, not a potency): "not active" (no number reported)
Nothing numeric was reported for compound 4; there is nothing to compare the estimate with.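

Among the compounds shown here, compound 4 gives "not active" (no number reported) and so offers no number, which means no step from compound 3 can be read. Going by these compounds, how far replacing methoxy with fluoro lowers inhibition remains open. No measurement shown offers an explanation for this result.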